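The compounds below may be only part of what the source reports. "The series", "measured", "known", "first", "only" and "open" are said of these compounds alone.

Working notes on the series. Three compounds of the shared core have been run in a functional assay for inhibition, with a stated time of 5 min, tested at 1 mM; on this read-out lower numbers stand for less inhibition and higher numbers for more inhibition at the one concentration tested (going by the name of the read-out). Compound 1 `COc1ccc(/C(Cl)=C/C=C(\C#N)C(=O)c2c(C)[nH]c3ccccc23)cc1` gives 63.1% in this assay. Compound 3 `COc1ccc(/C(Cl)=C/C=C(\C#N)C(=O)c2c[nH]c3ccccc23)cc1OC` gives 63.6% in this assay. Compound 2 `N#C/C(=C\C=C(/Cl)c1ccc(Br)cc1)C(=O)c1c[nH]c2ccc(Br)cc12` gives 83.6% in this assay, the highest of the three numbers; its gap to compound 3 and its gap to compound 1 are both beyond the scatter, so compound 2 stands clearly above the other two. Compound 1 and compound 3 lie within the scatter of each other and are not ordered here.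

Compound 4 `COc1ccc2[nH]cc(C(=O)/C(C#N)=C/C=C(\Cl)c3ccc(Br)cc3)c2c1` has not yet been measured. It differs from compound 2 in one place: methoxy in place of bromo on an aromatic carbon. For the measured compounds named here, no pair of measured compounds differs by this single change, so there is no measured step to rest on; compound 1 and compound 3 each differ from compound 2 in more than one place and also carry no bromo on the core. Given that both of them sit below compound 2 in this assay, compound 4 is expected to move downward from compound 2, by a modest step that may still fall within the scatter. The expected step is a number 12.6 percentage points lower from compound 2 to compound 4 (beyond the scatter). Compound 4 is thus estimated at 71%, with a range from 55% to 86%.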

Compound 4, a percentage reported as inhibition, at one concentration (the size of the read-out at that concentration, not a potency): 54.5%
Estimate against measurement, compound 4: 16.5 percentage points above; measured number outside the range, below it.
By their numbers in this assay, from the lowest: compounds 4, 1 and 3 (each within the scatter of the next); then compound 2.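

Between compounds that differ in one place, the series now holds a single step: in this assay, methoxy in place of bromo on an aromatic carbon, meta to a fused ring and para to a fused ring, gives a number 29.1 percentage points lower from compound 2 to compound 4 (beyond the scatter) at the one concentration tested. For the compounds shown here, this shows that the number in this assay depends on which of these two groups sits at this position of the shared core, something the earlier compounds could not show, since no two of them differed in one place only. No measurement at hand accounts for the size or direction of this step.

Whether bromo itself is needed at this position remains open, as the compounds shown do not tell how chloro, hydroxy, an amine or a carboxylic acid would read there, nor whether a longer chain such as ethoxy would follow methoxy. Also open, as far as these compounds go, is whether the same exchange on the other aromatic ring, which carries bromo in both compounds of this pair, would give a step of similar size.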